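The source may hold more compounds than are shown below. What is called first, only, known or untested is meant among the compounds shown, and "the series" means these compounds.

Measured compounds:
compound 1 `c1ccc(OCCCCCCOc2cccc(-c3cc4cc(C5=NCCN5)ccc4o3)c2)cc1` — in an ADME assay on L6 cells (Rattus norvegicus) for cytotoxicity, read by resazurin assay, with a stated time of 70 h (a lower number here means a stronger inhibitor, a higher number a weaker inhibitor), compound 1 gives 2500 nM
compound 2 `CC(C)NC(=N)c1ccc2oc(-c3ccc(OCCCOc4ccccc4)cc3)cc2c1` — in this assay compound 2 gives 45600 nM
compound 3 `c1ccc(OCCCOc2ccc(-c3cc4cc(C5=NCCN5)ccc4o3)cc2)cc1` — in this assay compound 3 gives 10300 nM

Compound 3 holds the second highest number of the three in this assay. Its nearest neighbour is compound 1, which sits lower; the furthest is compound 2, which sits higher. Going by the values given here, the only step between compounds that differ in one place is a 4.4-fold lower number from compound 2 to compound 3 (0.65 log units; beyond the scatter), and it concerns the group on the aromatic carbon of the shared core, not the linking chain.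

Compound 4 `c1ccc(OCCCCOc2ccc(-c3cc4cc(C5=NCCN5)ccc4o3)cc2)cc1` is reached from compound 3 by one change: phenoxymethyl in place of phenoxy on a saturated chain carbon, three bonds along the chain from an oxygen on an aromatic ring. Among the compounds with values here, no measured step bears on this change. Within the data shown here, compound 1 and compound 3 differ in both the chain and the placement of the phenoxy-bearing ring, so their two values show only that the longer-chain compound has the lower number, without separating the two differences. On that thin basis, the account expects a small step, toward a lower number, not clearly beyond the scatter, namely a 1.5-fold lower number from compound 3 to compound 4 (0.17 log units; within the scatter). Compound 4 is therefore estimated at 7000 nM, with a range from 3000 nM to 20000 nM.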

Compound 4, half-maximal inhibitory concentration: 2900 nM
Compound 4: the middle estimate sits 2.4-fold (0.38 log units) above what was measured; the measured number lies below the stated range.
By their numbers in this assay, from the lowest: compounds 1 and 4 (each within the scatter of the next); then compound 3; then compound 2.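

The step from phenoxy to phenoxymethyl in this assay is a 3.6-fold lower number from compound 3 to compound 4 (0.55 log units; beyond the scatter), which shows that the number responds to the linking chain alone, with the group on the aromatic carbon of the shared core left unchanged. Going by these compounds alone, the only earlier step between compounds differing in one place, a 4.4-fold lower number from compound 2 to compound 3 (0.65 log units; beyond the scatter), concerned that group and said nothing about the chain, whereas this one shows that a change on the saturated chain carbon can move the number beyond the scatter, here toward a lower number, even though the leaving and entering groups carry the same aromatic ring and the same hydrogen-bond counts. No supporting measurement accounts for the size or direction of this step.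

The compounds shown leave open whether 2-phenoxyethyl or 3-phenoxypropyl at this same place would carry the number further in the same direction, or whether it would level off or turn back. They also leave open how an amine or a carboxylic acid on the terminal ring would read in this assay, and whether the chain change would give a similar step in a compound carrying the open-chain group of compound 2.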